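The source may hold more compounds than are shown below. What is called first, only, known or untested is meant among the compounds shown, and "the series" means these compounds.

In a functional assay on CAL-27 cells (Homo sapiens) for antiproliferative activity, read by MTT assay, with a stated time of 72 h (a lower number here means a stronger inhibitor, a higher number a weaker inhibitor), compound 1 (`O=C(CCCCCONC(=O)Nc1cccc2ccccc12)NO`) gives 1600 nM and sits within the scatter of both compound 2 (`O=C(CCCCCONC(=O)Nc1cccc2cccnc12)NO`, at 1100 nM) and compound 3 (`Cc1ccc2cccc(NC(=O)NOCCCCCC(=O)NO)c2n1`, at 2200 nM), so the three cannot be ranked. Compound 4 (`CN(O)C(=O)CCCCCONC(=O)Nc1cccc2ccccc12`) departs from compound 1 only by methyl in place of hydrogen on an amide-type nitrogen, which turns hydroxycarbamoyl into hydroxy(methyl)carbamoyl. Among the measured compounds shown here, the one measured methyl step (a 2.0-fold higher number from compound 2 to compound 3 (0.30 log units; within the scatter)) lies within the scatter, but that methyl stands on an aromatic carbon, so it says little about this change. All three measured compounds carry the same hydroxycarbamoyl group, and no measurement shows what altering it does. The expected step (a 7.5-fold higher number from compound 1 to compound 4 (0.88 log units; beyond the scatter)) therefore rests on the nature of the change alone, and it is expected to go to a higher number, beyond the scatter, with wide uncertainty. Compound 4 is expected at 12000 nM (estimated range 3500 nM to 40000 nM).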

Compound 4, half-maximal inhibitory concentration: 43700 nM
Estimate against measurement, compound 4: 3.6-fold (0.56 log units) below, outside the stated range (above it).
By their numbers in this assay, from the lowest: compounds 2, 1 and 3 (each within the scatter of the next); then compound 4.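

In this assay, methyl in place of hydrogen on an amide-type nitrogen, which turns hydroxycarbamoyl into hydroxy(methyl)carbamoyl, gives a 27-fold higher number from compound 1 to compound 4 (1.44 log units; beyond the scatter). This is the only step shown that alters the hydroxycarbamoyl group, and it shows that the number at this position responds strongly to a single added carbon, whereas the earlier methyl step, on an aromatic carbon, stayed within the scatter. Nothing given here bears on why the number rises at this nitrogen.

The compounds shown leave open whether ethyl on the same nitrogen, or a carboxylic acid in place of the hydroxycarbamoyl group, would behave as methyl does. They also leave open whether this methyl would give a step of similar size on compound 2 or compound 3.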